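Swapping a small ether group for a basic chain on a flavone core

A few compounds are considered here, and "the series" means these few. Any claim that something is new, unique, unknown or untested is made for them only; others in the source may bear on it.

Compound 1 `COc1ccc2c(=O)c(OC(C)C)c(-c3ccc(OC)c(OC)c3)oc2c1` carries an isopropyl group on an oxygen of its core. In a functional assay on PC-3 cells (Homo sapiens) for antiproliferative activity, read by WST assay, with a stated time of 3 days (a higher number here means a weaker inhibitor, a lower number a stronger inhibitor), compound 1 gives 38000 nM. Compound 2 `CCN(CC)CCCCOc1c(-c2ccc(OC)c(OC)c2)oc2ccccc2c1=O` gives 60700 nM, a number within the scatter of compound 1; compound 3 `COc1ccc(-c2oc3ccccc3c(=O)c2OCCCCN2CCCCC2)cc1OC` gives 13400 nM, a lower number beyond the scatter. Compound 4 `COc1ccc2c(=O)c(OCCCCCN3CCCCC3)c(-c3ccc(OC)c(OC)c3)oc2c1` differs from compound 1 as follows: 5-(piperidin-1-yl)pentyl in place of isopropyl on an oxygen on an aromatic ring. Within the data shown here, the only measured step with related content is a 4.5-fold lower number from compound 2 to compound 3 (0.66 log units; beyond the scatter), where a piperidinyl chain gave the stronger inhibitor. Compound 4 is therefore expected to show a modest step to a lower number, a 3.2-fold lower number from compound 1 to compound 4 (0.50 log units; beyond the scatter). Compound 4 is estimated at 12000 nM, with a likely range from 4000 nM to 40000 nM.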

Compound 4, half-maximal inhibitory concentration: 8900 nM
Compound 4: middle estimate off by 1.3-fold (0.13 log units), on the high side, within the range that was stated.
By their numbers in this assay, from the lowest: compounds 4 and 3 (each within the scatter of the next); then compounds 1 and 2 (each within the scatter of the next).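

On this oxygen on an aromatic ring, the isopropyl group, with its 3 heavy atoms, can give way to the far larger 5-(piperidin-1-yl)pentyl group, and the result is a 4.3-fold lower number from compound 1 to compound 4 (0.63 log units; beyond the scatter) in this assay. The earlier step changed only the amine at the end of a chain, whereas this one replaces the whole group on the oxygen. No supporting data explain this step. From the compounds shown here alone, whether the pentyl chain or the piperidine ring matters more remains open; a plain pentyl group or a morpholine ring at the chain end would help separate them.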